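This account rests on a few compounds, and the source may have more. Where it says the series, first, only, none or still open, it means among the compounds named here.

Compound 1 `Cc1ccc2c(c1)[n+]([O-])c(NCCN(C)C)n[n+]2[O-]` is the starting point. In a physicochemical assay for solubility, in the presence of a further agent that is not named here (on this read-out higher numbers stand for higher solubility and lower numbers for lower solubility), compound 1 gives > 51000000 nM, which is a limit of the assay rather than a measured number. Compound 2 `CCN(CC)CCNc1n[n+]([O-])c2ccc(C)cc2[n+]1[O-]` likewise reaches a limit in this assay, giving > 49000000 nM. Compound 3 `Cc1ccc2c(c1)[n+]([O-])c(NCCN1CCCCC1)n[n+]2[O-]` gives a measured number in this assay, 45000000 nM. The step that the two limits leave unreadable from compound 1 to compound 2 cannot be read, since both of its values are limits the limit of > 51000000 nM in this assay, at which 1 of the 3 values shown sits (the limit of > 49000000 nM in this assay, at which 1 of the 3 values shown sits). The step of an at least 1.1-fold lower number from compound 1 to compound 3 (0.05 log units; that floor lies within the scatter) and the step of an at least 1.0-fold lower number from compound 2 to compound 3 (0.03 log units; that floor lies within the scatter) are only floors, and each floor sits within the scatter. Compound 4 `CC(C)Oc1ccc2c(c1)[n+]([O-])c(NCCN(C)C)n[n+]2[O-]` differs from compound 1 at a different place: isopropoxy in place of methyl on an aromatic carbon. For the measured compounds named here, none of the measured steps touches this aromatic carbon; all three alter the group at the end of the saturated chain, and all three read as flat or unreadable, so they offer no direction for the change to compound 4. Compound 4 is therefore expected to remain near the top of what this assay reports, with an estimated step of an at least 1.1-fold lower number from compound 1 to compound 4 (0.05 log units; that floor lies within the scatter). The estimate for compound 4 is 45000000 nM, within a range from 20000000 nM to 80000000 nM.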

Compound 4, solubility: > 51000000 nM
Compound 4: only a limit was reported; the forecaster's own chance of this, stated with the estimate: 40%; middle value at least 1.1-fold (0.05 log units) away from the limit.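

In this assay compound 4, like compound 1, stands at a limit rather than a measured number, so the step from compound 1 to compound 4 cannot be read. The compounds shown leave open the size and direction of any change in this assay when isopropoxy replaces methyl on an aromatic carbon.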